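This account rests on a few compounds, and the source may have more. Where it says the series, first, only, none or still open, it means among the compounds named here.

In a functional assay on THP-1 cells (Homo sapiens) for cytotoxicity, read by MTT assay, with a stated time of 24 h (on this read-out higher numbers stand for weaker inhibition and lower numbers for stronger inhibition), compound 1 `CCCCn1cc(Cn2nc(N)c3c(C(F)(F)F)cc(-c4ccccc4)nc32)nn1` gives 46.1 ug/mL, and compound 2 `Nc1nn(Cc2cn(CC(=O)Nc3ccc(F)cc3)nn2)c2nc(-c3ccccc3)cc(C(F)(F)F)c12` gives 49.6 ug/mL. Compound 2 stands alongside compound 1 on this read-out: the step of a 1.1-fold higher number from compound 1 to compound 2 (0.03 log units; within the scatter) lies within the scatter, so the two numbers cannot be separated, and compound 2 has no other neighbour to compare with.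

Compound 3 `Nc1nn(Cc2cn(CC(=O)Nc3ccc(F)cc3Br)nn2)c2nc(-c3ccccc3)cc(C(F)(F)F)c12` differs from compound 2 by bromo in place of hydrogen on an aromatic carbon; read one bond further out, the (4-fluorophenyl)carbamoyl becomes a (2-bromo-4-fluorophenyl)carbamoyl. Among the measured compounds shown here, the only measured step exchanged a propyl for a (4-fluorophenyl)carbamoyl and read a 1.1-fold higher number from compound 1 to compound 2 (0.03 log units; within the scatter); it does not place a bromo anywhere, so no measured step bears directly on the present change. With a single step in hand, and that one within the scatter, there is no ground to expect movement in this assay beyond the scatter in either direction; the expected step is a 1.1-fold lower number from compound 2 to compound 3 (0.04 log units; within the scatter). Compound 3 is therefore estimated at 45 ug/mL in this assay, with a range from 22 ug/mL to 90 ug/mL.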

Compound 3, half-maximal inhibitory concentration: 65.6 ug/mL
The estimate for compound 3 lay 1.5-fold (0.16 log units) below the measured number; low and high end bracket the measured number.
By their numbers in this assay, from the lowest: compounds 1, 2 and 3 (each within the scatter of the next).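

In this assay, placing a bromo on an aromatic carbon of the six-membered ring, ortho to a large group and meta to the fluoro group, gives a 1.3-fold higher number from compound 2 to compound 3 (0.12 log units; within the scatter), so this first change on that ring cannot be told apart from repeat-measurement noise. The larger exchange, (2-bromo-4-fluorophenyl)carbamoyl in place of propyl, gives a 1.4-fold higher number from compound 1 to compound 3 (0.15 log units; within the scatter), and this wider step also stays within the scatter, so even the two compounds furthest apart in structure here cannot be separated on this read-out. No supporting measurement is available to explain how these changes relate to the cell read-out.

Going by these compounds, with all three compounds within the scatter of one another, it remains open whether any change to this ring can shift the read-out beyond the scatter at all. A chloro, a methoxy or an amine on the same aromatic carbon, or a carboxylic acid in place of the whole aryl amide, would test whether this tolerance extends beyond the single bromo shown here.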